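This account rests on a few compounds, and the source may have more. Where it says the series, first, only, none or still open, it means among the compounds named here.

Measured compounds:
`NC1=NC2(CCSCC2)N(OCCCOc2ccc(Cl)c(Cl)c2)C(N)=N1`, compound 1: 89.8%
`NC1=NC2(CCSCC2)N(OCCCOc2ccc(Br)cc2)C(N)=N1`, compound 2: "not determined" (no result reported)

In an assay on isolated protein for inhibition of Dihydrofolate reductase (Homo sapiens), read by spectrophotometry, using NADPH, with stated times of 5 s and 6 min, tested at 50 uM (a lower number here means a weaker effect, a higher number a stronger effect of the compound at the concentration tested), compound 1 gives 89.8%. For compound 2 the outcome in this assay is reported as "not determined" (no result reported), so compound 2 stands with no single number to its name. Compound 3, `NC1=NC2(CCSCC2)N(OCCCOc2cccc(Cl)c2Cl)C(N)=N1`, differs from compound 2 in one place: 2,3-dichlorophenyl in place of 4-bromophenyl on an oxygen on a saturated carbon. Among the compounds with values here, since compound 2 has no value, no step between compound 2 and compound 3 can be drawn in this assay. Within the data shown here, the only measured reference is compound 1 with its 89.8%, and any shift of compound 3 from that reading is expected to stay within the scatter, in either direction. Compound 3 is therefore estimated at 85%, in the range 65% to 96%.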

Compound 3, a percentage reported as inhibition, at one concentration (the size of the read-out at that concentration, not a potency): 89.8%
Compound 3: middle estimate off by 4.8 percentage points, on the low side; measured number inside the range.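

In this assay, 2,3-dichlorophenyl in place of 3,4-dichlorophenyl on an oxygen on a saturated carbon gives no change at the digits printed from compound 1 to compound 3 (within the scatter). At this position, then, the two dichlorophenyl groups cannot be told apart at the single concentration tested, a reading that is not a potency. No available evidence accounts for this result.

With no value for compound 2, its steps cannot be read, so 4-bromophenyl stays uncompared. Also open, going by these compounds, is how an unsubstituted phenyl, a pyridine or a longer chain would read at this position.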